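Extending the Chain in a Series Tolerated by Cells

The compounds below may be only part of what the source reports. "The series", "measured", "known", "first", "only" and "open" are said of these compounds alone.

Compound 3 `CCc1ncnc(NC(C)c2ccc(C(C)(C)C)cc2)c1Cl` stands only at a limit in an ADME assay on HEK-293T cells (Homo sapiens) for cytotoxicity, with a stated time of 48 h; a lower number here means that less compound is tolerated, a higher number that more compound is tolerated: compound 3 gives > 10000 nM, which is a limit of the assay and not a number. Compound 1 `CCc1ncnc(NC(CC)c2ccc([N+](=O)[O-])cc2)c1Cl` gives > 10000 nM in this assay, likewise a limit. Compound 2 `CCc1ncnc(NC(CC)c2ccc(N(C)C)cc2)c1Cl` gives > 10000 nM, again a limit. The step that the two limits leave unreadable from compound 1 to compound 2 therefore cannot be read in size, as the two limits hide it. All three values sit at the limit of > 10000 nM in this assay, at which 3 of the 3 values shown sit.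

Compound 4 `CCc1ncnc(NC(CC)c2ccc(C(C)(C)C)cc2)c1Cl` differs from compound 3 by methyl in place of hydrogen on a saturated chain carbon, two bonds along the chain from an aromatic carbon and a nitrogen on an aromatic ring; cut one bond further out, this reads methyl to ethyl. Going by the values given here, no measured step bears directly on this change, and the only measured step, a step that the two limits leave unreadable from compound 1 to compound 2, is unreadable. With every value at the limit, no step beyond the scatter is expected in this assay, and the expected step that the limit leaves unreadable from compound 3 to compound 4 is none. Compound 4 is estimated at 15000 nM, between 8000 nM and 40000 nM, and is expected most likely to be reported again only as a limit.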

Compound 4, half-maximal cytotoxic concentration: > 10000 nM
Compound 4: only a limit was reported; the forecaster's own chance of this, stated with the estimate: 80%; the middle value does not contradict the limit.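

None of the steps from compound 1, compound 2 or compound 3 to compound 4 can be read in this assay, as each pair shows two limits and not numbers: the limit of > 10000 nM in this assay, at which 4 of the 4 values shown sit.

The compounds shown leave open at what concentration any of them becomes cytotoxic, and whether methyl to ethyl alters that concentration.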